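The source may hold more compounds than are shown below. What is called first, only, known or untested is meant among the compounds shown, and "the series" means these compounds.

In a functional assay on LS174T cells (Homo sapiens) for antiproliferative activity (a higher number here means a weaker inhibitor, a lower number a stronger inhibitor), compound 1 (`CNc1ncc(/C=C/c2c(F)cccc2F)cn1`) is reported only as a limit, > 200 nM. Compound 2 (`CNc1ncc(/C=C/c2c(F)cccc2Cl)cn1`) is also reported only as a limit, > 200 nM. The series therefore offers so far only (the limit of > 200 nM in this assay, at which 2 of the 2 values shown sit), and compound 2 has no number of its own. Compound 3 (`CNc1ncc(/C=C/c2c(Cl)cccc2Cl)cn1`) differs from compound 2 by a single exchange: chloro in place of fluoro on an aromatic carbon. Among the compounds with values here, one measured step bears on this change, since it is also chloro in place of fluoro on an aromatic carbon: a step that the two limits leave unreadable from compound 1 to compound 2. That step provides no size or direction to carry over, so no definite shift can be predicted in this assay, and compound 3 is expected to stay weak, probably near the same limit. The expected change is a step that the limit leaves unreadable from compound 2 to compound 3. Compound 3 is estimated at 300 nM, with an expected range from 80 nM to 1500 nM.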

Compound 3, half-maximal inhibitory concentration: > 200 nM
Compound 3 was reported as a limit (the forecaster's own chance of this, stated with the estimate: 60%); the middle value does not contradict the limit.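

In this assay, compound 2 is reported only as a limit, > 200 nM. Within the data shown here, compound 3 is also only a limit, > 200 nM, so no step between compound 2 and compound 3 can be read. Going by these compounds, whether chloro in place of fluoro on an aromatic carbon changes activity at all, in either direction, stays open.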